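Methylcarbamoyl to carbamoyl on the pyridine amide

This account rests on a few compounds, and the source may have more. Where it says the series, first, only, none or still open, it means among the compounds named here.

Measured compounds:
- Compound 1, `CNC(=O)c1cncc(NS(=O)(=O)c2cc(Cl)ccc2OC)c1`: 109 nM
- Compound 2, `COc1ccc(OC)c(S(=O)(=O)Nc2cncc(-c3ccncc3)c2)c1`: 73 nM

Of the compounds shown here, two have been measured in an assay on isolated protein for inhibition of alkaline phosphatase, tissue-nonspecific isozyme (Homo sapiens); a lower number here means a stronger inhibitor, a higher number a weaker inhibitor. Compound 1 gives 109 nM, the higher of the two numbers, while compound 2 gives 73 nM; the gap between them lies within the usual scatter, so the two cannot be ranked. Compound 3, `COc1ccc(Cl)cc1S(=O)(=O)Nc1cncc(C(N)=O)c1`, has not yet been measured. It differs from compound 1 in one place: hydrogen in place of methyl on an amide-type nitrogen. Going by the values given here, no step between measured compounds shows what such a change does on this core, so nothing beyond the structures themselves can guide the expectation. A small group leaving an amide nitrogen is expected to move the number little; the step of a 1.0-fold higher number from compound 1 to compound 3 (0.00 log units; within the scatter) is estimated to lie within the scatter, in no particular direction. The value for compound 3 in this assay is therefore estimated at 110 nM, ranging from 45 nM to 270 nM.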

Compound 3, half-maximal inhibitory concentration: 16 nM
Beside the measured number, compound 3's estimate is 6.9-fold (0.84 log units) above it, and the stated range ends above it.
By their numbers in this assay, from the lowest: compound 3; then compounds 2 and 1 (each within the scatter of the next).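

In this assay, the methyl on the amide-type nitrogen proves not to be a silent group: hydrogen in its place gives a 6.8-fold lower number from compound 1 to compound 3 (0.83 log units; beyond the scatter), a step beyond the scatter. Going by these compounds alone, this is the first single change that can be read on the shared core, and it shows that the methylcarbamoyl to carbamoyl change at this position moves the number clearly towards a stronger inhibitor. No measurement among those available explains this step.

As far as these compounds go, what stays open is how the nitrogen responds to groups other than hydrogen and methyl, such as an ethyl group or a longer chain, and whether a carboxylic acid or a nitrile in place of the whole carbamoyl would hold the lower number. This single pair also cannot say whether the same change gives a similar step on another core.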